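This account rests on a few compounds, and the source may have more. Where it says the series, first, only, none or still open, it means among the compounds named here.

In a functional assay on J774 cells (Mus musculus) for cytotoxicity (a higher number here means a weaker inhibitor, a lower number a stronger inhibitor), compound 3 `CCCN(CCC)c1c([N+](=O)[O-])cc(S(=O)(=O)Nc2cc(Cl)cc(Cl)c2)cc1[N+](=O)[O-]` gives 5100 nM, the lowest of three numbers, while compound 1 `CCCN(CCC)c1c([N+](=O)[O-])cc(S(=O)(=O)Nc2ccc(OC)cc2)cc1[N+](=O)[O-]` gives 15000 nM and compound 2 `CCCN(CCC)c1c([N+](=O)[O-])cc(S(=O)(=O)Nc2cccc(OC)c2)cc1[N+](=O)[O-]` gives 25000 nM. Compound 4 `CCCN(CCC)c1c([N+](=O)[O-])cc(S(=O)(=O)N(C)c2ccccc2)cc1[N+](=O)[O-]` is still unmeasured. It carries methyl(phenyl)amino in place of (3,5-dichlorophenyl)amino on a sulfonyl sulfur. The closest evidence is the arrival of the dichlorinated ring, which gave a 2.9-fold lower number from compound 1 to compound 3 (0.47 log units; beyond the scatter) and a 4.9-fold lower number from compound 2 to compound 3 (0.69 log units; beyond the scatter), both modest. The two methoxy-bearing compounds differ by only a 1.7-fold higher number from compound 1 to compound 2 (0.22 log units; within the scatter). Among the compounds with values here, no measured compound tests the added methyl, so the estimate is uncertain. Removing the chlorines may reverse a step of that modest size, so the expected change is a 2.7-fold higher number from compound 3 to compound 4 (0.44 log units; beyond the scatter). For compound 4 the estimated value is 14000 nM, with an expected range of 5000 nM to 35000 nM.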

Compound 4, half-maximal inhibitory concentration: 11000 nM
Compound 4: middle estimate off by 1.3-fold (0.10 log units), on the high side; the measured number falls inside the stated range.
By their numbers in this assay, from the lowest: compound 3; then compounds 4, 1 and 2 (each within the scatter of the next, the first and the last beyond it).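

In this assay the methyl(phenyl)amino group, which has no hydrogen-bond donor, gives a 2.2-fold higher number from compound 3 to compound 4 (0.33 log units; beyond the scatter) against (3,5-dichlorophenyl)amino and a 2.3-fold lower number from compound 2 to compound 4 (0.36 log units; beyond the scatter) against (3-methoxyphenyl)amino, so compound 4 sits between these two. Against (4-methoxyphenyl)amino there is a 1.4-fold lower number from compound 1 to compound 4 (0.13 log units; within the scatter) and thus no real difference, so losing the hydrogen on the sulfonamide nitrogen does not set compound 4 apart from compound 1. Nothing shown explains these steps. A phenylamino group on the sulfonyl sulfur would separate the effect of the methyl from that of the lost ring substituents. As far as these compounds go, an ethyl group on that nitrogen also remains open.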